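The compounds below may be only part of what the source reports. "The series", "measured", "known", "first", "only" and "open" are said of these compounds alone.

The measured compounds:
compound 1, `CC(C)C[C@H](N)c1ccccc1N1CCN(C(=O)[C@H](C)Cc2ccc(Cl)cc2F)CC1`, gives 67 nM in an assay on HEK293 cells for displacement of a labelled ligand from Melanocortin receptor 4 (Homo sapiens); a lower number here means a stronger inhibitor, a higher number a weaker inhibitor.
compound 2, `CC(C)C[C@H](N)c1cc(C(F)(F)F)ccc1N1CCN(C(=O)C(C)Cc2ccc(Cl)c(Cl)c2)CC1`, gives 120 nM; 1600 nM (2 entries) in this assay.
compound 3, `CC(C)C[C@H](N)c1cc(C(F)(F)F)ccc1N1CCN(C(=O)CCC(N)=O)CC1`, gives > 10000 nM in this assay.

Compound 3 stands apart from the other two. Its result is a limit of the assay and not a number: in this assay compound 3 shows > 10000 nM, and it has one further entry without a single number (the limit of > 10000 nM in this assay, at which 1 of the 3 values shown sits). Compound 1 and compound 2 both carry a branched chain with a halogenated phenyl ring on the amide, and both give numbers inside the measured range, although compound 2 has scattered entries (the several entries of compound 2 in this assay, 120 nM; 1600 nM (2 entries)).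

Compound 4, `CC(C)C[C@H](N)c1cc(C(F)(F)F)ccc1N1CCN(C(=O)CC(C)C(=O)c2ccc(Cl)cc2)CC1`, keeps the core of compound 3 and changes only the chain on the amide: 1-((4-chlorophenyl)carbonyl)ethyl in place of carbamoylmethyl on a saturated chain carbon bound to a carbonyl carbon. In plain terms, a short chain ending in a primary amide is exchanged for a longer, branched chain that carries a ketone and a chlorophenyl ring. That brings compound 4 closer in build to compound 1 and compound 2, which both hold a halogenated phenyl ring on a branched chain and both give numbers in this assay.

The step from compound 3 to compound 4 is expected to be a clear gain, well beyond the scatter, an at least 20-fold lower number from compound 3 to compound 4 (1.30 log units; beyond the scatter). Compound 2 reaches 120 nM; 1600 nM (2 entries) with a related halogenated chain, with the scatter among its entries noted (the several entries of compound 2 in this assay, 120 nM; 1600 nM (2 entries)). Going by these compounds, the ketone in compound 4 is untested and adds uncertainty. Compound 4 is therefore estimated at 500 nM, with a range from 80 nM to 4000 nM.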

Compound 4, inhibition constant: 1100 nM
Compound 4: the middle estimate sits 2.2-fold (0.34 log units) below what was measured, within the range that was stated.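

In this assay, among the compounds shown here, putting 1-((4-chlorophenyl)carbonyl)ethyl in place of carbamoylmethyl on a saturated chain carbon bound to a carbonyl carbon gives an at least 9.0-fold lower number from compound 3 to compound 4 (0.95 log units; beyond the scatter), the first direct evidence that the group at this place affects the result, since no earlier pair differed in one place only. Compound 3 has only a limit of the assay and not a number, so the step gives a minimum and its full size stays unknown because of that limit: the limit of > 10000 nM in this assay, at which 1 of the 4 values shown sits. The change also alters several things at once, bringing in a chlorophenyl ring and a ketone while removing the hydrogen-bond donor of the primary amide, and this single step cannot show which of these parts accounts for the gain.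

Going by these compounds, it remains open whether the ketone matters, which a compound with a plain methylene or an alcohol at that carbon, and the chlorophenyl ring kept, could help to settle. On these data alone, it is equally open how an amine or a carboxylic acid at the end of the chain would compare with the primary amide of compound 3.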